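The source may report more compounds than this note shows. Statements on the series, on what has been measured and on what is new or still open speak of the compounds shown alone.

Measured compounds:
- compound 1 `CCOc1ccc(Cc2ccc(NC3=NCCN3)cc2)cc1` — in a functional assay on SH-SY5Y cells (Homo sapiens) for antagonist activity, read by cAMP accumulation (on this read-out higher numbers stand for higher potency (the scale is a negative logarithm) and lower numbers for lower potency), compound 1 gives 8.2
- compound 2 `COCCOc1ccc(Cc2ccc(NC3=NCCN3)cc2)cc1` — in this assay compound 2 gives 8

Compound 1 stands highest of the two numbers, with compound 2 nearest: a number 0.20 log units lower from compound 1 to compound 2 (within the scatter).

Compound 3 `c1cc(NC2=NCCN2)ccc1Cc1ccc(OCC2CCOCC2)cc1` differs from compound 1 in one place: oxan-4-yl in place of methyl on a saturated chain carbon bound to an oxygen on an aromatic ring. Among the compounds with values here, the change therefore sits on the same ethoxy chain that the one measured step already touched. That step, a number 0.20 log units lower from compound 1 to compound 2 (within the scatter), added a methoxy on the chain carbon two bonds from the ring oxygen and moved the number only within the scatter. Within the data shown here, it is the only step that bears on compound 3, and it gives no sign that building out this chain shifts the read-out either way. The step of a number 0.20 log units lower from compound 1 to compound 3 (within the scatter) is thus expected to stay within the scatter, with no clear direction. For compound 3 in this assay the estimate is 8, with a range from 7.4 to 8.6.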

Compound 3, negative logarithm of the antagonist equilibrium constant: 8.5
For compound 3 the middle estimate is 0.50 log units below the measured one; the measured number falls inside the stated range.
By their numbers in this assay, from the lowest: compounds 2, 1 and 3 (each within the scatter of the next, the first and the last beyond it).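

On the saturated chain carbon bound to an oxygen on an aromatic ring, the change from ethoxy to (oxan-4-yl)methoxy is accommodated in this assay, with a number 0.30 log units higher from compound 1 to compound 3 (within the scatter), so this place holds a much larger group that includes a ring without a clear loss or gain. Within the data shown here, with methoxymethyl as the group replaced, the same place gives the only step that clears the scatter, a number 0.50 log units higher from compound 2 to compound 3 (beyond the scatter), which shows that the choice of group here can register on this read-out. No measurement at hand accounts for either step.

The three compounds do not separate the contribution of the ring from that of its oxygen, a question that cyclohexylmethoxy could address. On these data alone, how this place responds to a longer chain such as butoxy, to an amine such as piperidin-4-ylmethoxy, or to a carboxylic acid remains open.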